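A few compounds are considered here, and "the series" means these few. Any claim that something is new, unique, unknown or untested is made for them only; others in the source may bear on it.

Compound 1 `O=C1OCc2cc(OCc3ccc(Cl)cc3)ccc21` and compound 2 `O=C1OCc2cc(OCc3ccc(F)cc3)ccc21` share one core and are set side by side in an assay on isolated protein for inhibition of Amine oxidase [flavin-containing] A (Homo sapiens), read by fluorescence, with a stated time of 15 min; a higher number here means a weaker inhibitor, a lower number a stronger inhibitor. There compound 2 gives 1330 nM and compound 1 gives 3610 nM, a step of a 2.7-fold higher number from compound 2 to compound 1 (0.43 log units; beyond the scatter); the change is chloro in place of fluoro on an aromatic carbon. Compound 3 `CC(=O)c1ccc(OCc2ccc(F)cc2)cc1F` sits on a different core, and how its core differs from that of compound 2 is not broken down here. In this assay compound 3 gives only a limit, > 100000 nM, which is the limit of > 100000 nM in this assay, at which 1 of the 3 values shown sits. Compound 4 `CC(=O)c1ccc(OCc2ccc(Cl)cc2)cc1F` is made from compound 3 by chloro in place of fluoro on an aromatic carbon, the same change as that from compound 2 to compound 1. Since compound 3 already stands at the limit and the same change weakened inhibition in the measured pair, compound 4 is expected to give 200000 nM, a step that the limit leaves unreadable from compound 3 to compound 4, most likely again as a limit.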

Compound 4, half-maximal inhibitory concentration: 89100 nM
For compound 4 the middle estimate is 2.2-fold (0.35 log units) above the measured one; the range from low to high includes it.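

In this assay, chloro in place of fluoro on an aromatic carbon gives an at least 1.1-fold lower number from compound 3 to compound 4 (0.05 log units; that floor lies within the scatter). Set beside the same change on the other core, the step does not carry over with one size and direction, and the two steps stand apart by more than the scatter: the same change on two cores in this assay, a 2.7-fold higher number (0.43 log units; beyond the scatter) from compound 2 to compound 1 and an at least 1.1-fold lower number (0.05 log units; that floor lies within the scatter) from compound 3 to compound 4, at least 3.0-fold (0.48 log units) apart, beyond the scatter of two such steps

From the compounds shown here alone, compound 3 gives only a limit, > 100000 nM; the full size of the step on its core stays unknown, and one pair on each core cannot show why the two differ or how the change behaves on other cores.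

The compounds shown leave open how a bromo group, a nitrile or an amine in place of the halogen would read in this assay. They also leave open whether either core would follow the same course with such groups.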